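This account rests on a few compounds, and the source may have more. Where it says the series, first, only, none or still open, it means among the compounds named here.

Measured so far:
compound 1 `CC1=C(C(=O)OCc2ccccc2)C(c2ccc(-c3ccccc3)cc2)N(CCCCCC(=O)O)C(=S)N1` — 110000 nM
compound 2 `CC1=C(C(=O)OCc2ccccc2)C(c2ccc(-c3ccccc3)cc2)NC(=S)N1CCCCCC(=O)O` — 100000 nM

In a toxicity assay on RMS13 cells (Homo sapiens) for inhibition, with a stated time of 24 h (a higher number here means a weaker inhibitor of growth, a lower number a stronger inhibitor of growth), compound 1 gives 110000 nM, nominally the higher of the two numbers, but compound 2 gives 100000 nM, which lies within the scatter of compound 1, so the two are not separable. Compound 3 `CC1=C(C(=O)OCc2ccccc2)C(c2ccc(-c3ccccc3)cc2)N(Cc2ccc(-c3nnn[nH]3)cc2)C(=S)N1` is not yet measured. It differs from compound 1 by 4-(1H-tetrazol-5-yl)phenyl in place of 4-carboxybutyl on a saturated chain carbon bound to an amide-type nitrogen in a ring. Among the measured compounds shown here, no measured pair covers a change of this kind, and both known values sit at the weak end of the scale. The expected step from compound 1 to compound 3 is a 1.4-fold lower number from compound 1 to compound 3 (0.14 log units; within the scatter). Compound 3 is estimated at 80000 nM, with a range from 20000 nM to 300000 nM.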

Compound 3, concentration for 50% growth inhibition: 72000 nM
The estimate for compound 3 lay 1.1-fold (0.05 log units) above the measured number; the measured number falls inside the stated range.
By their numbers in this assay, from the lowest: compounds 3, 2 and 1 (each within the scatter of the next).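

In this assay the exchange of 4-carboxybutyl for 4-(1H-tetrazol-5-yl)phenyl, on a saturated chain carbon bound to an amide-type nitrogen in a ring, gives a 1.5-fold lower number from compound 1 to compound 3 (0.18 log units; within the scatter), the first step read at this position. A chain without a ring and a group with two aromatic rings therefore cannot be told apart here, and all values stay at the weak end of the scale. Nothing available explains why these two groups read alike. Still open, as far as these compounds go, is whether a primary amine or an unsubstituted phenyl in the same place would stay within the scatter of compound 1.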